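The compounds below may be only part of what the source reports. "The series", "measured", "known", "first", "only" and "open" are said of these compounds alone.

The series centres on compound 1 `CC(C)[C@@H](NC(=O)/C=C/c1ccncc1-c1ccc2ccccc2c1)C(=O)O`, a cinnamic acid derivative of the shared core coupled to an amino acid. In an assay on a protein complex for inhibition of CDK8/Cyclin C (Homo sapiens), with a stated time of 1 h (on this read-out lower numbers stand for stronger inhibition and higher numbers for weaker inhibition), compound 1 is recorded as "not determined" (no result reported), so its own standing cannot be given. Two neighbours of the same type were measured. In this assay compound 2 `Cn1ccc2cc(-c3cnccc3/C=C/C(=O)O)ccc21` gives 26.8 nM, and in this assay compound 3 `CNC(=O)/C=C/c1ccncc1-c1ccc2cccnc2c1` gives 1760 nM; compound 2 carries the free acid, compound 3 a methyl amide, and the two values lie far apart.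

Compound 4 `O=C(O)/C=C/c1ccncc1-c1ccc2ccccc2c1` is reached from compound 1 by the change (hydroxy in place of (1-carboxy-2-methylpropyl)amino on a carbonyl carbon). For the measured compounds named here, since compound 1 carries no value, no step can be sized from it, and the expectation for compound 4 rests on compound 2, whose value 26.8 nM belongs to a free acid, and on compound 3, whose weaker value 1760 nM belongs to an amide. Compound 4, as a free acid, is estimated at 60 nM, with a range from 10 nM to 400 nM.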

Compound 4, half-maximal inhibitory concentration: 5 nM
Estimate against measurement, compound 4: 12-fold (1.08 log units) above; measured number outside the range, below it.
By their numbers in this assay, from the lowest: compound 4; then compound 2; then compound 3.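

No step can be read from compound 1 to compound 4, since compound 1 has no single number in this assay. The compounds shown leave open how (1-carboxy-2-methylpropyl)amino compares with hydroxy on that carbonyl carbon. No evidence bearing on the result is available.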